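Working notes: methoxy on the phenyl of compound 2

A few compounds are considered here, and "the series" means these few. Any claim that something is new, unique, unknown or untested is made for them only; others in the source may bear on it.

Measured so far in this series:
compound 1 `CCc1nc(N)c2nn(-c3ccccc3)cc2n1`: 38%
compound 2 `Nc1nc(CCc2ccccc2)nc2cn(-c3ccccc3)nc12`: 17%

In an assay on CHO cells for displacement of a labelled ligand from adenosine receptor A3 (Homo sapiens), read by scintillation counting, tested at 1 uM (a higher number here means more inhibition at the concentration tested (going by the name of the read-out), a lower number less inhibition), compound 2 gives 17%, the lower of the two numbers recorded. The nearest point is compound 1 at 38%. For the measured compounds named here, the only step between measured compounds runs a number 21 percentage points lower from compound 1 to compound 2 (beyond the scatter), that is phenyl in place of hydrogen on a saturated chain carbon, two bonds along the chain from an aromatic carbon.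

Compound 3 `COc1ccc(CCc2nc(N)c3nn(-c4ccccc4)cc3n2)cc1` differs from compound 2 by methoxy in place of hydrogen on an aromatic carbon. Going by the values given here, no measured step concerns a substituent on that phenyl; the one step available changes the chain end itself and does not speak to this change. The expectation for this assay is therefore a step within the usual scatter in either direction, a number 3 percentage points higher from compound 2 to compound 3 (within the scatter). The estimate for compound 3 is 20%, with a range from 5% to 40%.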

Compound 3, a percentage reported as inhibition, at one concentration (the size of the read-out at that concentration, not a potency): 22%
For compound 3 the middle estimate is 2 percentage points below the measured one, and the stated range covers the measured number.
By their numbers in this assay, from the lowest: compounds 2 and 3 (each within the scatter of the next); then compound 1.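

In this assay the phenyl at the chain end receives its first measured substituent: phenyl to 4-methoxyphenyl gives a number 5 percentage points higher from compound 2 to compound 3 (within the scatter) and so does not separate the two compounds at this position. The step from the ethyl chain survives the added methoxy, with a number 16 percentage points lower from compound 1 to compound 3 (beyond the scatter) as the reading, so compound 2 and compound 3 both stand apart from compound 1. No other information on record bears on these numbers.

From the compounds shown here alone, whether a hydroxyl, a chlorine or an amine on the same aromatic carbon would behave as methoxy does remains open, as does the effect of methoxy on another carbon of that ring. Also open, going by these compounds, is whether a longer chain carrying the phenyl, or a shorter one, would change the reading.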